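Trading one hydroxy-alkoxyphenyl hydrazone for another

A few compounds are considered here, and "the series" means these few. Any claim that something is new, unique, unknown or untested is made for them only; others in the source may bear on it.

Compound 1 `O=C(N/N=C/c1ccco1)c1cccc(S(=O)(=O)N2CCOCC2)c1` carries a furan-2-yl group on the carbon double-bonded to nitrogen. In a functional assay on MGC-803 cells (Homo sapiens) for antiproliferative activity, read by MTT assay, with a stated time of 72 h (on this read-out higher numbers stand for weaker inhibition and lower numbers for stronger inhibition), compound 1 reaches only a limit, > 100000 nM. Compound 2 `COc1ccc(/C=N/NC(=O)c2cccc(S(=O)(=O)N3CCOCC3)c2)c(O)c1` carries a 2-hydroxy-4-methoxyphenyl there instead, and in this assay compound 2 gives 2070 nM, the only number shown. Among the measured compounds shown here, the single measured step, an at least 48-fold lower number from compound 1 to compound 2 (1.68 log units; beyond the scatter), starts from the limit of > 100000 nM in this assay, at which 1 of the 2 values shown sits. Compound 3 `CCOc1cccc(/C=N/NC(=O)c2cccc(S(=O)(=O)N3CCOCC3)c2)c1O` differs from compound 2 by 3-ethoxy-2-hydroxyphenyl in place of 2-hydroxy-4-methoxyphenyl on a carbon with a double bond to nitrogen. For the measured compounds named here, no measured step covers a swap of one hydroxy-alkoxyphenyl for another, so the change from compound 2 to compound 3 is expected to stay within the scatter, a 1.2-fold higher number from compound 2 to compound 3 (0.08 log units; within the scatter). Compound 3 is estimated at 2500 nM, between 600 nM and 10000 nM.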

Compound 3, half-maximal inhibitory concentration: 18000 nM
For compound 3 the middle estimate is 7.2-fold (0.86 log units) below the measured one, outside the stated range (above it).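

The two groups both carry a hydroxy and an alkoxy, yet they are not interchangeable at this position: in this assay, 3-ethoxy-2-hydroxyphenyl in place of 2-hydroxy-4-methoxyphenyl gives an 8.7-fold higher number from compound 2 to compound 3 (0.94 log units; beyond the scatter). The 3-ethoxy-2-hydroxyphenyl group still does better than furan-2-yl, with an at least 5.5-fold lower number from compound 1 to compound 3 (0.74 log units; beyond the scatter). That step is a minimum, set by a limit: the limit of > 100000 nM in this assay, at which 1 of the 3 values shown sits.

The swap changes both the alkoxy chain and its place on the ring, and the compounds shown cannot separate the two. As far as these compounds go, how an amine in place of the hydroxy, or a longer propoxy chain, would fare also stays open.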